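Replacing 4-cyanophenyl with 2-chlorophenyl in a small series

The source may hold more compounds than are shown below. What is called first, only, known or untested is meant among the compounds shown, and "the series" means these compounds.

Compound 1 `COc1ccc(NC(=S)NC2CC(C)(C)Oc3ccc(Br)cc32)cc1`: "not determined" (no result reported)
Compound 2 `CC1(C)CC(NC(=S)Nc2ccc(Cl)cc2)c2cc(Br)ccc2O1`: 7000 nM
Compound 3 `CC1(C)CC(NC(=S)Nc2ccc(C#N)cc2)c2cc(Br)ccc2O1`: "not determined" (no result reported)

In a functional assay on B16-F10 cells (Mus musculus) for inhibition, read by MTT assay, with a stated time of 72 h (a higher number here means a weaker inhibitor, a lower number a stronger inhibitor), compound 3 has no usable number, since its entry reads "not determined" (no result reported). The same holds for compound 1, so only compound 2 offers a value, 7000 nM.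

The next structure is compound 4 `CC1(C)CC(NC(=S)Nc2ccccc2Cl)c2cc(Br)ccc2O1`, with 2-chlorophenyl in place of 4-cyanophenyl on an amide-type nitrogen.

Going by the values given here, no measured pair shows how large such a swap can be, so the expected size is a judgement. Compound 2, at 7000 nM, also carries chlorine on its phenyl ring. A result near that value is therefore expected in this assay, with no shift in either direction beyond the usual scatter.

For compound 4 the estimated value is 7000 nM, with an expected range from 2500 nM to 20000 nM.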

Compound 4, half-maximal inhibitory concentration: 17000 nM
Compound 4: the middle estimate sits 2.4-fold (0.39 log units) below what was measured; the measured number falls inside the stated range.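

With the same chlorine atom on the phenyl ring, going from 4-chlorophenyl to 2-chlorophenyl on the amide-type nitrogen gives a 2.4-fold higher number from compound 2 to compound 4 (0.39 log units; beyond the scatter) in this assay. This first readable step at this position shows that where the chlorine sits on the ring changes the result, with compound 4 the weaker inhibitor of the two. The swap from 4-cyanophenyl itself cannot be read, and nothing available explains the step.

On these data alone, what an amine or a carboxylic acid on this phenyl ring would give remains open.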